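Swapping one ring atom on a sulfonyl-bound side chain

This account rests on a few compounds, and the source may have more. Where it says the series, first, only, none or still open, it means among the compounds named here.

Measured so far:
- compound 1 `O=S(=O)(CC1=NCCS1)C1C(c2ccccc2)=NN(c2ccccc2)C1c1ccccc1`: "not active" (no number reported)
- compound 2 `O=S(=O)(CC1=NCCO1)c1c(-c2ccccc2)nn(-c2ccccc2)c1-c1ccccc1`: 57.3%

The measurements come from a functional assay, tested at 75 ug/mL; a higher number here means a stronger effect of the compound at the concentration tested, a lower number a weaker effect. Compound 1 `O=S(=O)(CC1=NCCS1)C1C(c2ccccc2)=NN(c2ccccc2)C1c1ccccc1` is reported in this assay as "not active" (no number reported), so no single number marks where it stands; it is simply recorded as showing no effect at the tested concentration. Compound 2 `O=S(=O)(CC1=NCCO1)c1c(-c2ccccc2)nn(-c2ccccc2)c1-c1ccccc1` differs from compound 1 in several places, not in one place only. In this assay compound 2 gives 57.3%. Among the compounds with values here, no single-change step between compound 1 and compound 2 can be drawn, and the two results only show that one of the pair has a measurable effect and the other does not.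

Compound 3 `O=S(=O)(CC1=NCCO1)C1C(c2ccccc2)=NN(c2ccccc2)C1c1ccccc1` has not yet been measured. It differs from compound 1 in one place only: a group of 5 heavy atoms (3 carbon, 1 nitrogen, 1 oxygen; one five-membered non-aromatic ring with 2 hetero atoms) in place of a group of 5 heavy atoms (3 carbon, 1 nitrogen, 1 sulfur; one five-membered non-aromatic ring with 2 hetero atoms), on a saturated chain carbon bound to a sulfonyl sulfur. Since compound 1 carries no number, the size of this step in this assay cannot be computed; with a starting point of no effect, a shift of modest size upward, or none beyond the scatter, is the expectation. Compound 3 is estimated to give 20% in this assay, within a range from 0% to 50%.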

Compound 3, a percentage reported as activity, at one concentration (the size of the read-out at that concentration, not a potency): 45.5%
Beside the measured number, compound 3's estimate is 25.5 percentage points below it; low and high end bracket the measured number.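

Within the data shown here, compound 1 carries no number, so no step to compound 3 can be read from this result. Nothing measured here offers an explanation for the result. The compounds shown leave open how large the effect of exchanging the sulfur-containing five-membered ring for the oxygen-containing one is, and whether it would hold on other cores.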